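The source may report more compounds than this note shows. Statements on the series, on what has been measured and on what is new or still open speak of the compounds shown alone.

Compound 1 `C=C[C@@](C)(/C=C/c1ccc(Nc2ccccc2)cc1)CCC=C(C)C` carries an anilino group on the shared core. In a functional assay on NALM-6 cells (Homo sapiens) for cytotoxicity, with a stated time of 72 h (on this read-out lower numbers stand for an effect already at smaller amounts and higher numbers for an effect only at larger amounts of compound), compound 1 reaches only a limit, > 43400 nM, and no number beneath it is known. Compound 2 `C=C[C@@](C)(/C=C/c1ccc(Nc2cccc(OC(F)(F)F)c2)cc1)CCC=C(C)C` differs by trifluoromethoxy in place of hydrogen on an aromatic carbon; in this assay compound 2 likewise stops at the limit > 43400 nM. Compound 3 `C=C[C@@](C)(/C=C/c1ccc(Nc2cc(F)c(F)cc2F)cc1)CCC=C(C)C` has 2,4,5-trifluorophenyl in place of phenyl on a nitrogen on an aromatic ring, and in this assay compound 3 also shows only the limit > 43400 nM. Both measured steps, a step that the two limits leave unreadable from compound 1 to compound 2 and a step that the two limits leave unreadable from compound 1 to compound 3, are therefore unreadable in size and direction because every value sits at the limit of > 43400 nM in this assay, at which 3 of the 3 values shown sit.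

Compound 4 `C=C[C@@](C)(/C=C/c1ccc(-c2ccc(F)cc2)cc1)CCC=C(C)C` brings the change (4-fluorophenyl in place of anilino on an aromatic carbon). Among the compounds with values here, no measured step bears on this change: the two steps known for the series give no size at all, so nothing points to a movement beyond the scatter in either direction, and no step beyond the scatter is expected in this assay. The most likely outcome for compound 4 is again a limit rather than a number.

For compound 4 the estimate in this assay is 50000 nM, within 20000 nM to 150000 nM. The implied step is expected to be a step that the limit leaves unreadable from compound 1 to compound 4.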

Compound 4, half-maximal effective concentration: > 43400 nM
Compound 4: no number, only a limit; the forecaster's own chance of this, stated with the estimate: 80%; the middle value does not contradict the limit.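

In this assay compound 4 gives > 43400 nM, which is a limit and not a number. The step from compound 1 to compound 4 cannot be read, because compound 1 and compound 4 both stop at the same limit: the limit of > 43400 nM in this assay, at which 4 of the 4 values shown sit.

The compounds shown leave open whether any change on the shared core gives a measurable value in this assay.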